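Longer isothiocyanate chains on two related cores

The source may hold more compounds than are shown below. What is called first, only, known or untested is meant among the compounds shown, and "the series" means these compounds.

Of the compounds shown here, three have been measured in a functional assay on NCI-H1299 cells (Homo sapiens) for inhibition, read by CCK-8 assay, with a stated time of 72 h, tested at 1 uM (on this read-out lower numbers stand for a weaker effect and higher numbers for a stronger effect at the one concentration tested), and a fourth awaits its measurement. Compound 1 `CN(C)C(=O)c1cc2cnc(Nc3ccc(S(=O)(=O)NCCCN=C=S)cc3)nc2n1C1CCCC1` gives 41.3% in this assay. Compound 2 `CN(C)C(=O)c1cc2cnc(Nc3ccc(S(=O)(=O)NCCCCN=C=S)cc3)nc2n1C1CCCC1` gives 29.9% in this assay. The two differ in one place: a group of 4 heavy atoms (2 carbon, 1 nitrogen, 1 sulfur; no ring) in place of a group of 3 heavy atoms (1 carbon, 1 nitrogen, 1 sulfur; no ring), on a saturated chain carbon, three bonds along the chain from a sulfonamide nitrogen. This step, a number 11.4 percentage points lower from compound 1 to compound 2 (beyond the scatter), is therefore a loss of effect.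

Compound 3 `CN(C)C(=O)c1cc2cnc(Nc3ccc(C(=O)NCCCN=C=S)cc3F)nc2n1C1CCCC1` gives 9.27% in this assay, the lowest of the three numbers. The difference between the core of compound 3 and the core of compound 1 is not broken down here.

Compound 4 `CN(C)C(=O)c1cc2cnc(Nc3ccc(C(=O)NCCCCN=C=S)cc3F)nc2n1C1CCCC1` is not yet measured. It stands to compound 3 as compound 2 stands to compound 1: a group of 4 heavy atoms (2 carbon, 1 nitrogen, 1 sulfur; no ring) in place of a group of 3 heavy atoms (1 carbon, 1 nitrogen, 1 sulfur; no ring), on a saturated chain carbon, three bonds along the chain from an amide-type nitrogen. The surroundings are not the same word for word, since in compound 1 the chain carbon sits three bonds along the chain from a sulfonamide nitrogen, while in compound 3 it sits three bonds along the chain from an amide-type nitrogen, so this is the same kind of change rather than the same change.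

The expectation for compound 4 rests on compound 1 and compound 2, whose step is a number 11.4 percentage points lower from compound 1 to compound 2 (beyond the scatter), and on compound 3, which already gives 9.27% in this assay. From that low starting point a further drop of similar size cannot fully appear, so the estimated step is a number 6.3 percentage points lower from compound 3 to compound 4 (within the scatter). Compound 4 is estimated to give 3% in this assay, expected to lie between -7% and 14%.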

Compound 4, a percentage reported as inhibition, at one concentration (the size of the read-out at that concentration, not a potency): 28.7%
For compound 4 the middle estimate is 25.7 percentage points below the measured one; the measured number lies above the stated range.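

On the core of compound 3, the longer chain brings a number 19.4 percentage points higher from compound 3 to compound 4 (beyond the scatter) in this assay, which is the opposite direction to the step seen on the core of compound 1. The same change therefore does not carry over from one core to the other in this series, and the effect of lengthening the chain cannot be assumed from one core when judging the other: the same change on two cores in this assay, a number 11.4 percentage points lower (beyond the scatter) from compound 1 to compound 2 and a number 19.4 percentage points higher (beyond the scatter) from compound 3 to compound 4, 30.8 percentage points apart, beyond the scatter of two such steps What this does not show is the reason for the reversal: the core of compound 1 and the core of compound 3 differ in more than one place, and a single pair of compounds on each core cannot say which of those differences matters.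

Going by these compounds, it remains open whether the sulfonyl group, the carbonyl group or the fluorine decides the direction of the step, a question that only compounds differing from each other in just one of these places could answer. Also open is how these cores would read with a longer chain than the ones shown, or with a simple amine in place of the isothiocyanate at the end of the chain.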